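Hydroxy to fluoro on the methoxyphenyl series

The source may report more compounds than this note shows. Statements on the series, on what has been measured and on what is new or still open speak of the compounds shown alone.

In a functional assay on SK-OV-3 cells (Homo sapiens) for inhibition (a lower number here means a stronger inhibitor of growth, a higher number a weaker inhibitor of growth), compound 1 (`COc1ccc(-n2cnnc2-c2cc(OC)c(OC)c(OC)c2)cc1`) gives 6460 nM, and compound 2 (`COc1ccc(-n2cnnc2-c2cc(OC)c(OC)c(OC)c2)cc1O`) gives 316 nM, the lower of the two numbers. Compound 3 (`COc1ccc(-n2cnnc2-c2cc(OC)c(OC)c(OC)c2)cc1F`) carries fluoro in place of hydroxy on an aromatic carbon, ortho to a methoxy group: fluoro in place of hydroxy on an aromatic carbon. Among the measured compounds shown here, the only measured step bearing on this change, a 20-fold lower number from compound 1 to compound 2 (1.31 log units; beyond the scatter), is large and brought in the hydroxy that now leaves, so a clear move to a higher number in this assay is expected, probably smaller than that step. The expected step is a 3.8-fold higher number from compound 2 to compound 3 (0.58 log units; beyond the scatter). Compound 3 is estimated at 1200 nM, with a range of 280 nM to 5500 nM.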

Compound 3, concentration for 50% growth inhibition: 8320 nM
Estimate against measurement, compound 3: 6.9-fold (0.84 log units) below, and the stated range ends below it.
By their numbers in this assay, from the lowest: compound 2; then compounds 1 and 3 (each within the scatter of the next).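

Fluoro does not reproduce the hydroxy effect at this position in this assay, with the exchange giving a 26-fold higher number from compound 2 to compound 3 (1.42 log units; beyond the scatter) and the comparison with hydrogen giving a 1.3-fold higher number from compound 1 to compound 3 (0.11 log units; within the scatter) as its printed result. Among the three compounds, only hydroxy on this aromatic carbon separates from the others, so the low number is tied to that group and not to any substitution here. No measurement available bears on the reason.

On these data alone, whether an amine or a hydroxymethyl group at this position would match hydroxy remains open. So does whether an amide or a carboxylic acid would be tolerated here.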